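The source may hold more compounds than are shown below. What is called first, only, known or untested is meant among the compounds shown, and "the series" means these compounds.

Series notes. Compound 1 `O=S(=O)(Nc1cc(-c2cnc3[nH]nc(-c4ccccc4)c3c2)cnc1Cl)c1ccccc1` and compound 2 `O=S(=O)(Nc1cc(-c2cnc3[nH]cc(-c4ccccc4)c3c2)cnc1Cl)c1ccccc1` share one core and differ only within the fused five-membered ring. In a functional assay on U-87MG ATCC cells for inhibition, with U-87 MG (Homo sapiens) as the target, read by sulforhodamine B assay, with a stated time of 72 h (a lower number here means a stronger inhibitor of growth, a higher number a weaker inhibitor of growth), compound 1 gives > 10000 nM, which is a limit of the assay and not a number. In this assay compound 2 gives > 10000 nM, again a limit rather than a measured number. Going by the values given here, both values thus sit at the limit of > 10000 nM in this assay, at which 2 of the 2 values shown sit, so no step between measured compounds can be read, and where compound 2 stands on the scale is known only as that limit. Compound 3 `O=S(=O)(Nc1cc(-c2cnc3[nH]cc(-c4ccncc4)c3c2)cnc1Cl)c1ccccc1` is the next member: pyridin-4-yl in place of phenyl on an aromatic carbon. Among the compounds with values here, the two values so far give no direction for such a change and no size beyond the scatter. For compound 3 the expected step is a step that the limit leaves unreadable from compound 2 to compound 3, with the result most likely reported once more as a limit. The estimate for compound 3 in this assay is 15000 nM, within a range from 6000 nM to 40000 nM.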

Compound 3, concentration for 50% growth inhibition: 8950 nM
Compound 3: the middle estimate sits 1.7-fold (0.22 log units) above what was measured; the range from low to high includes it.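

Going by these compounds alone, compound 3 is the first member of the series to give a measured number rather than a limit in this assay, at 8950 nM. At this aromatic carbon of the five-membered ring, pyridin-4-yl in place of phenyl gives an at least 1.1-fold lower number from compound 2 to compound 3 (0.04 log units; that floor lies within the scatter). Whether the full step lies beyond the scatter cannot be read, because compound 2 is known only as a limit: the limit of > 10000 nM in this assay, at which 2 of the 3 values shown sit.

The compounds shown leave open whether a ring nitrogen placed elsewhere, as in pyridin-3-yl, or a group such as an amine or a carboxylic acid on the six-membered ring at this carbon would give a lower number. Also open, on these data alone, is whether pyridin-4-yl would give a measured number on the core of compound 1, whose fused five-membered ring differs.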